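Replacing 4-nitrophenyl in compound 2: expectation for compound 4

A few compounds are considered here, and "the series" means these few. Any claim that something is new, unique, unknown or untested is made for them only; others in the source may bear on it.

Measured so far in a functional assay on MCF7 cells (Homo sapiens) for inhibition, read by MTT assay; a higher number here means a weaker inhibitor of growth, a lower number a stronger inhibitor of growth:
- compound 1 `COc1cc2oc(-c3cccc(NC(=O)c4cccc(Br)c4)c3)cc(=O)c2c(OC)c1OC`: 6340 nM
- compound 2 `COc1cc2oc(-c3cccc(NC(=O)c4ccc([N+](=O)[O-])cc4)c3)cc(=O)c2c(OC)c1OC`: 20100 nM
- compound 3 `COc1cc2oc(-c3cccc(NC(=O)c4ccc(C)cc4)c3)cc(=O)c2c(OC)c1OC`: 8320 nM

Compound 2 gives the highest number of the three, and its distance to each of the other two lies beyond the scatter. Compound 1 and compound 3 do not separate, with a 1.3-fold higher number from compound 1 to compound 3 (0.12 log units; within the scatter).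

The next compound is compound 4 `COc1ccccc1C(=O)Nc1cccc(-c2cc(=O)c3c(OC)c(OC)c(OC)cc3o2)c1`. The change from compound 2 is 2-methoxyphenyl in place of 4-nitrophenyl on a carbonyl carbon whose other neighbours are: amide-type nitrogen.

Within the data shown here, no measured compound carries 2-methoxyphenyl, so no measured step shows this change directly. Among the measured compounds shown here, two steps bear on it by involving 4-nitrophenyl: a 3.2-fold higher number from compound 1 to compound 2 (0.50 log units; beyond the scatter) and a 2.4-fold lower number from compound 2 to compound 3 (0.38 log units; beyond the scatter). Both are modest, and in both the compound with 4-nitrophenyl has the higher number. On three compounds this is thin evidence, but a modest step to a lower number in this assay is expected, of about the size of a 2.4-fold lower number from compound 2 to compound 3 (0.38 log units; beyond the scatter). The expected step is a 2.1-fold lower number from compound 2 to compound 4 (0.33 log units; beyond the scatter). For compound 4 the estimated value is 9500 nM, with an expected range of 4000 nM to 22000 nM.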

Compound 4, concentration for 50% growth inhibition: 15300 nM
Beside the measured number, compound 4's estimate is 1.6-fold (0.21 log units) below it; measured number inside the range.
By their numbers in this assay, from the lowest: compounds 1, 3, 4 and 2 (each within the scatter of the next, the first and the last beyond it).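

In this assay, among these compounds, 2-methoxyphenyl on the carbonyl carbon does not separate from 4-nitrophenyl (a 1.3-fold lower number from compound 2 to compound 4 (0.12 log units; within the scatter)) or from 4-methylphenyl (a 1.8-fold higher number from compound 3 to compound 4 (0.26 log units; within the scatter)), so compound 4 overlaps two groups that the earlier compounds had held apart, and the amide aryl groups here do not fall into two clean levels. Only 3-bromophenyl stands apart from 2-methoxyphenyl, and the step is modest (a 2.4-fold higher number from compound 1 to compound 4 (0.38 log units; beyond the scatter)), which leaves the whole span at this position small across four different aryl groups. Nothing measured here accounts for these numbers.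

Among the compounds shown here, the four aryl groups differ both in the substituent and in where it sits on the ring, so no pair isolates either one, and a matched pair such as 2-methoxyphenyl with 4-methoxyphenyl would separate the two. The compounds shown also leave open how the number responds to an amine or a carboxylic acid on this ring, or to a saturated ring such as cyclohexyl in place of the phenyl.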